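A chloro to bromo swap, awaiting its number

The source may report more compounds than this note shows. Statements on the series, on what has been measured and on what is new or still open speak of the compounds shown alone.

Of the compounds shown here, two have numbers so far in an ADME assay on Huh-7 cells (Homo sapiens) for cytotoxicity, read by MTT assay, with a stated time of 72 h (a lower number here means that less compound is tolerated, a higher number that more compound is tolerated), and they set the frame for a third. Compound 1 (`Cc1cccc(C(=O)NO)c1`) reads 340000 nM while compound 2 (`O=C(NO)c1ccc(Cl)cc1`) reads 55000 nM and so holds the lower of the two numbers, with a gap to compound 1 that lies beyond the usual scatter. The two differ in more than one place, so no measured single change is available as a guide.

Compound 3 (`O=C(NO)c1ccc(Br)cc1`) is the one still to be read. Against compound 2 its structure changes in one place (bromo in place of chloro on an aromatic carbon), with bromo in place of chloro on an aromatic carbon. Compound 2 at 55000 nM is therefore the closest measured structure and serves as the anchor. The step expected in this assay is none beyond the scatter, with no firm direction, and the estimated change a 1.1-fold lower number from compound 2 to compound 3 (0.04 log units; within the scatter) is small. The estimate for compound 3 is 50000 nM (expected range 20000 nM to 125000 nM).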

Compound 3, half-maximal cytotoxic concentration: 25000 nM
For compound 3 the middle estimate is 2.0-fold (0.30 log units) above the measured one; measured number inside the range.
By their numbers in this assay, from the lowest: compound 3; then compound 2; then compound 1.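

Among these compounds, the swap of chloro for bromo on an aromatic carbon, para to a group of 4 heavy atoms, is the first measured single change in this set, and in this assay it gives a 2.2-fold lower number from compound 2 to compound 3 (0.34 log units; beyond the scatter) as a modest step. This shows that the position is not indifferent to which of these two halogens it carries: one heavy atom is exchanged for one heavy atom, with no ring, hydrogen-bond donor, hydrogen-bond acceptor or net charge entering or leaving, and the number still moves towards less compound tolerated. Nothing at hand bears on the reason for this step.

The compounds shown leave open whether iodo at this place would continue the direction seen from chloro to bromo, and whether a non-halogen group there, such as an amine or a carboxylic acid, would move the number at all. They also leave open whether the same swap would give a step of similar size at another place on the ring, as both halogens are seen at this one place only.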